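A few compounds are considered here, and "the series" means these few. Any claim that something is new, unique, unknown or untested is made for them only; others in the source may bear on it.

Measured compounds:
compound 1, `CCCCCCCCCCC#Cc1cc2cn([C@@H]3O[C@H](CO)[C@@H](O)[C@@H]3O)c(=O)nc2o1`, gives 46000 nM in a functional assay on HEL cells (Homo sapiens) for cytotoxicity; on this read-out lower numbers stand for higher toxicity in this test and higher numbers for lower toxicity in this test
compound 2, `CCCCC#Cc1cc2cn([C@@H]3O[C@H](CO)[C@@H](O)[C@@H]3O)c(=O)nc2o1`, gives > 144000 nM in this assay

Compound 2 stands at the edge of what this assay can report. Going by these compounds, for compound 2 the value > 144000 nM is a limit of the assay and not a number; no cytotoxicity was seen up to that concentration, so the true number is unknown (the limit of > 144000 nM in this assay, at which 1 of the 2 values shown sits). Compound 1 gives 46000 nM, a number inside the range of the assay, and the step of an at least 3.1-fold higher number from compound 1 to compound 2 (0.49 log units; beyond the scatter) shows that taking the hexyl away is followed by lower toxicity.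

Compound 3, `CCCCCCC#Cc1cc2cn([C@@H]3O[C@H](CO)[C@@H](O)[C@@H]3O)c(=O)nc2o1`, differs from compound 2 by ethyl in place of hydrogen on a saturated chain carbon, four bonds along the chain from a triple-bonded carbon. This change runs back toward compound 1, though only part of the way, since compound 3 carries a shorter chain than compound 1. Among the compounds with values here, the one step that bears on it, an at least 3.1-fold higher number from compound 1 to compound 2 (0.49 log units; beyond the scatter), went in the direction of less toxicity when chain was removed, so adding chain is expected to bring a modest move toward more toxicity, possibly still leaving compound 3 at the limit. The step from compound 2 to compound 3 is estimated as an at least 1.3-fold lower number from compound 2 to compound 3 (0.11 log units; that floor lies within the scatter). Compound 3 is therefore expected to give 110000 nM, with a range from 50000 nM to 200000 nM.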

Compound 3, minimum cytotoxic concentration: 133000 nM
Estimate against measurement, compound 3: 1.2-fold (0.08 log units) below, within the range that was stated.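

Hydrogen in place of butyl, six bonds along the chain from a triple-bonded carbon, is followed by lower toxicity in this test, with a 2.9-fold higher number from compound 1 to compound 3 (0.46 log units; beyond the scatter) and, unlike the earlier step from compound 1, a number at both ends. For compound 2 the value > 144000 nM is a limit of the assay and not a number. Ethyl in place of hydrogen, four bonds along the chain from a triple-bonded carbon, gives an at least 1.0-fold lower number from compound 2 to compound 3 (0.03 log units; that floor lies within the scatter) and so sets no order between the two compounds, since how far compound 3 truly lies from compound 2 stays unknown: the limit of > 144000 nM in this assay, at which 1 of the 3 values shown sits.

The compounds shown leave open how the number in this assay moves for chains of a length between those of compound 3 and compound 1, and whether a longer chain than that of compound 1 would bring still higher toxicity in this test. They also leave open what an amine or a hydroxyl group on the chain, or a phenyl ring in its place, would do to this read-out.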